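The source may hold more compounds than are shown below. What is called first, only, known or untested is meant among the compounds shown, and "the series" means these compounds.

Measured compounds:
- Compound 1 `COc1ccc(/C=C/C(=O)/C=C/c2ccc(OCc3cn(CCCCOc4cc(=O)oc5ccccc45)nn3)c(OC)c2)cc1OC`: 55%
- Compound 2 `COc1cc(/C=C/C(=O)/C=C/c2cccs2)ccc1OCc1cn(CCOc2cc(=O)oc3ccccc23)nn1`: 71%
- Compound 3 `COc1cc(/C=C/C(=O)/C=C/c2cccs2)ccc1OCc1cn(CCCCCOc2cc(=O)oc3ccccc23)nn1`: 31%

All three values come from a functional assay on HCT-116 cells (Homo sapiens) for inhibition, read by sulforhodamine B assay, with a stated time of 48 h, tested at 50 uM; a lower number here means less inhibition of growth, a higher number more inhibition of growth at the concentration tested. Compound 1 sits in the middle of this small set at 55%. Compound 2 lies higher at 71% and compound 3 lies lower at 31%, and both gaps from compound 1 go beyond the usual scatter of the measurement.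

The next compound to be tested is compound 4 `COc1ccccc1/C=C/C(=O)/C=C/c1ccc(OCc2cn(CCCCOc3cc(=O)oc4ccccc34)nn2)c(OC)c1`, which is built from compound 1 by a single change: 2-methoxyphenyl in place of 3,4-dimethoxyphenyl on a double-bonded chain carbon bound to a double-bonded chain carbon. In words, 2-methoxyphenyl stands in place of 3,4-dimethoxyphenyl on a double-bonded chain carbon bound to a double-bonded chain carbon, and the rest of the molecule stays as it is in compound 1.

Among the compounds with values here, none of the measured compounds shows what this swap does, so the value of compound 1 at 55% is the only firm starting point. The wide spread across the three measured compounds also argues for a broad range. No step beyond the scatter is expected in this assay, and the estimated change is a number 3 percentage points lower from compound 1 to compound 4 (within the scatter). For compound 4 the expected value is 52%, with an estimated range from 32% to 72%.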

Compound 4, percent growth inhibition at one concentration: 43%
Estimate against measurement, compound 4: 9 percentage points above; the measured number falls inside the stated range.
By their numbers in this assay, from the lowest: compound 3; then compound 4; then compound 1; then compound 2.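

In this assay, placing 2-methoxyphenyl in place of 3,4-dimethoxyphenyl on a double-bonded chain carbon bound to a double-bonded chain carbon gives a number 12 percentage points lower from compound 1 to compound 4 (beyond the scatter). Within the data shown here, this is the first direct look at this position, and it shows that the number responds to the aromatic group placed here even when the rest of the molecule stays as it is in compound 1. The group that leaves has 10 heavy atoms and 2 hydrogen-bond acceptors, while the one that enters has 8 and 1, but no measurement at hand explains the drop.

The swap alters both the number of methoxy groups and where they sit on the ring, so these two differences cannot be told apart from compound 1 and compound 4 alone. On these data alone, how an unsubstituted phenyl, a 4-methoxyphenyl or a ring bearing a dimethylamino group would behave at this position stays open, as does whether the same swap would have a similar effect with a different chain length in the rest of the molecule.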